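Swapping a chain group for isopropyl in compound 1

The compounds below may be only part of what the source reports. "The series", "measured", "known", "first", "only" and "open" are said of these compounds alone.

Compound 1 has the structure `N=C(N)NCCC[C@H](NC(=O)CN(c1ncnc2c1ncn2C1CCCCO1)C1CC1)C(=O)OCc1ccccc1`. In a functional assay on the whole organism (Tail, strain ICR) with Mus musculus as the target, in the tail flick test, with a stated time of 30 min, at a dose of 25 umol/kg by the oral route (on this read-out higher numbers stand for a stronger effect at the one dose given and lower numbers for a weaker effect), compound 1 gives 34.3%. Two related compounds were measured alongside it: compound 2, `O=C(CN(c1nc(Cl)nc2[nH]cnc12)C1CC1)N[C@@H](CC(=O)OCc1ccccc1)C(=O)OCc1ccccc1`, which in this assay gives 34.7%, and compound 3, `NC(=O)CC[C@H](NC(=O)CN(c1nc(Cl)nc2[nH]cnc12)C1CC1)C(=O)O`, which gives 33.1%. All three values lie within the usual scatter of one another, so compound 1 cannot be set apart from either neighbour.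

Compound 4, `CC(C)C[C@H](NC(=O)CN(c1ncnc2c1ncn2C1CCCCO1)C1CC1)C(=O)OCc1ccccc1`, is not yet measured. It differs from compound 1 by the change (a group of 3 heavy atoms (3 carbon; no ring) in place of a group of 6 heavy atoms (3 carbon, 3 nitrogen; no ring), on a saturated chain carbon, two bonds along the chain from an amide-type nitrogen and a carbonyl carbon). For the measured compounds named here, no measured pair shows what such a swap does here, so no direction can be read from the data. The step from compound 1 to compound 4 is expected to be a number 1.3 percentage points lower from compound 1 to compound 4 (within the scatter), which is none beyond the scatter. Compound 4 is therefore estimated at 33%, with a range from 18% to 48%.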

Compound 4, a percentage reported as activity, at one dose (the size of the read-out at that dose, not a potency): 26.2%
Beside the measured number, compound 4's estimate is 6.8 percentage points above it, and the stated range covers the measured number.
By their numbers in this assay, from the lowest: compounds 4, 3, 1 and 2 (each within the scatter of the next).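

At this position, on a saturated chain carbon, two bonds along the chain from an amide-type nitrogen and a carbonyl carbon, putting isopropyl in place of the nitrogen-bearing group gives (a number 8.1 percentage points lower from compound 1 to compound 4 (within the scatter)) in this assay. This first step read at this position means that a group with no nitrogen and no hydrogen-bond donors can stand here without a change beyond the scatter. Nothing available explains this result.

On these data alone, whether an amine, a carboxylic acid or a longer chain at this carbon would also stay within the scatter remains open. A single dose also leaves open how these compounds would compare at other doses.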